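Swapping Benzyl for 2-Methylphenyl on the Amide Nitrogen

The source may hold more compounds than are shown below. What is called first, only, known or untested is meant among the compounds shown, and "the series" means these compounds.

The shared core is seen in compound 1 `O=C(Nc1ccccc1)c1cc2ccccc2oc1=O`, which in an assay on isolated protein for inhibition of coagulation factor XII (Homo sapiens) (a higher number here means a weaker inhibitor, a lower number a stronger inhibitor), gives 42000 nM. Compound 2 `Cc1ccc2oc(=O)c(C(=O)Nc3ccccc3)cc2c1` carries a methyl on an aromatic carbon, and in this assay compound 2 gives 23000 nM; the change is a 1.8-fold lower number from compound 1 to compound 2 (0.26 log units; within the scatter). Compound 3 `Cc1ccc2oc(=O)c(C(=O)NCc3ccccc3)cc2c1` has a benzyl on the amide-type nitrogen in place of phenyl. In this assay compound 3 reaches only a limit of the assay, > 50000 nM. The step is an at least 2.1-fold higher number from compound 2 to compound 3 (0.33 log units; beyond the scatter), and the weak position rests on (the limit of > 50000 nM in this assay, at which 1 of the 3 values shown sits).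

Compound 4 `Cc1ccc2oc(=O)c(C(=O)Nc3ccccc3C)cc2c1` differs from compound 3 in one place: 2-methylphenyl in place of benzyl on an amide-type nitrogen. This largely reverses the change from phenyl to benzyl, so the step of an at least 2.1-fold higher number from compound 2 to compound 3 (0.33 log units; beyond the scatter) bears on it in the opposite direction, while a 1.8-fold lower number from compound 1 to compound 2 (0.26 log units; within the scatter) suggests that a methyl on an aromatic carbon shifts little. A modest move to a lower number is therefore expected, an at least 2.0-fold lower number from compound 3 to compound 4 (0.30 log units; that floor lies within the scatter). Compound 4 is estimated at 25000 nM, with a range from 9000 nM to 70000 nM.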

Compound 4, half-maximal inhibitory concentration: 32000 nM
The estimate for compound 4 lay 1.3-fold (0.11 log units) below the measured number; low and high end bracket the measured number.
By their numbers in this assay, from the lowest: compounds 2, 4 and 1 (each within the scatter of the next). At a limit, above all of these: compound 3.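

Adding a methyl to an aromatic carbon of the phenyl on the amide-type nitrogen gives a 1.4-fold higher number from compound 2 to compound 4 (0.14 log units; within the scatter), so in this assay this place accepts the extra methyl with no change that can be read. Rearranging the same atoms from benzyl into 2-methylphenyl gives an at least 1.5-fold lower number from compound 3 to compound 4 (0.19 log units; that floor lies within the scatter), so this step cannot yet be called a real gain, even though the anilide-type link of compound 2 and compound 4 stays measurable. Compound 3 stands at a limit of the assay, so the full size of that step is unknown: the limit of > 50000 nM in this assay, at which 1 of the 4 values shown sits.

From the compounds shown here alone, what an amine or a carboxylic acid would do in place of this methyl remains open, as does a longer chain such as propyl. Going by these compounds, whether any of these would move the number beyond the scatter also remains open.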